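This account rests on a few compounds, and the source may have more. Where it says the series, first, only, none or still open, it means among the compounds named here.

Within the data shown here, in a functional assay on the whole organism for antagonist activity, with Mus musculus as the target (a lower number here means that less compound is needed, a higher number that more compound is needed for the effect), compound 3 `COc1ccc(CN2CCC(C(=O)Nc3cc(Cl)c(N)cc3OC)CC2)cc1` gives 0.9 mg/kg, the only firm number among the three measured compounds. Compound 1 `CCCCCCCN1CCC(C(=O)Nc2cc(Cl)c(N)cc2OC)CC1` reaches only the limit > 10 mg/kg. Compound 2 `COc1cc(N)c(Cl)cc1NC(=O)C1CCN(C2CCCC2)CC1` likewise stops at the limit > 10 mg/kg, so that the limit of > 10 mg/kg in this assay, at which 2 of the 3 values shown sit, is where most of the series sits. Compound 4 `COc1cc(N)c(Cl)cc1NC(=O)C1CCN(CC2CCCC2)CC1` differs from compound 3 by cyclopentyl in place of 4-methoxyphenyl on a saturated chain carbon bound to an amine nitrogen in a ring. Among the measured compounds shown here, two measured steps bear on this: an at least 11-fold lower number from compound 2 to compound 3 (1.04 log units; beyond the scatter) and an at least 11-fold lower number from compound 1 to compound 3 (1.04 log units; beyond the scatter), both large, both in favour of the aromatic group that compound 4 gives up for a saturated ring. A step of an 8.9-fold higher number from compound 3 to compound 4 (0.95 log units; beyond the scatter) is therefore expected, toward a higher dose. Compound 4 is estimated at 8 mg/kg in this assay. The expected range for compound 4 is estimated to run from 2 mg/kg to 30 mg/kg.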

Compound 4, dose for half-maximal effect: > 10 mg/kg
Compound 4: no number, only a limit (the forecaster's own chance of this, stated with the estimate: 45%); middle value at least 1.2-fold (0.09 log units) from the limit.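

In this assay, keeping the saturated chain carbon on the amine nitrogen and changing only 4-methoxyphenyl to cyclopentyl gives an at least 11-fold higher number from compound 3 to compound 4 (1.04 log units; beyond the scatter), so a ring at this place does not by itself preserve the effect; among these compounds, only compound 3, with its aromatic ring, gives a firm number. Compound 4 gives only a limit, like the others without that ring: the limit of > 10 mg/kg in this assay, at which 3 of the 4 values shown sit. The steps among compounds 1, 2 and 4 cannot be read, as all three values are limits.

As far as these compounds go, it remains open whether the aromatic ring alone is enough or the methoxy group is also needed. A plain benzyl group at this place would separate the two.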